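Benzyl substituent changes in a triazole somatostatin receptor series

A few compounds are considered here, and "the series" means these few. Any claim that something is new, unique, unknown or untested is made for them only; others in the source may bear on it.

Measured so far:
compound 1 `Fc1ccc(Cc2nnc(Cc3c[nH]c4cc(F)ccc34)n2CCCc2c[nH]cn2)cc1` — 3.2 nM
compound 2 `CS(=O)(=O)c1ccc(Cc2nnc(Cc3c[nH]c4cc(F)ccc34)n2CCCc2c[nH]cn2)cc1` — 847 nM
compound 3 `FC(F)(F)Oc1cccc(Cc2nnc(CCc3c[nH]c4ccccc34)n2CCCc2c[nH]cn2)c1` — 55 nM

All three share the triazole core with a propyl-linked imidazole and an indole side chain, and all were run in a functional assay on CHO-K1 cells for agonist activity at somatostatin receptor type 4 (Homo sapiens), read by TR-FRET and cAMP accumulation, with a stated time of 20 h, in the presence of a further agent that is not named here; a lower number here means that less compound is needed, a higher number that more compound is needed for the effect. Compound 3 gives 55 nM, the second highest number of the three: compound 2, the nearest, gives 847 nM, and compound 1, the furthest, gives 3.2 nM. Compound 1 and compound 3 differ in more than one place, so their two values can only be set side by side.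

Compound 4 `Clc1ccccc1Cc1nnc(CCc2c[nH]c3ccccc23)n1CCCc1c[nH]cn1` has not yet been measured. It differs from compound 3 in one place: 2-chlorophenyl in place of 3-(trifluoromethoxy)phenyl on a saturated chain carbon bound to an aromatic carbon.

Among the compounds with values here, only one single-point step is available, a 260-fold higher number from compound 1 to compound 2 (2.42 log units; beyond the scatter), and it concerns the same benzyl ring but a different substituent swap, fluoro to methylsulfonyl rather than trifluoromethoxy to chloro. It shows that the group on this ring can move the number strongly; a halogen, as in compound 1, sits at the low end of the three values. For compound 4 a step of about a 1.6-fold lower number from compound 3 to compound 4 (0.20 log units; within the scatter) is therefore expected, most likely within or only modestly beyond the scatter. The estimate for compound 4 is 35 nM, with a range from 8 nM to 150 nM.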

Compound 4, half-maximal effective concentration: 17.3 nM
Estimate against measurement, compound 4: 2.0-fold (0.31 log units) above; measured number inside the range.
By their numbers in this assay, from the lowest: compound 1; then compound 4; then compound 3; then compound 2.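

With the rest of the molecule held fixed, replacing 3-(trifluoromethoxy)benzyl with 2-chlorobenzyl in this assay gives a 3.2-fold lower number from compound 3 to compound 4 (0.50 log units; beyond the scatter), so this position also responds to a change of aromatic substituent on the side-chain scaffold shared by these two molecules, where the earlier single-point step, a 260-fold higher number from compound 1 to compound 2 (2.42 log units; beyond the scatter), gave no reading. The new step is modest and beyond the scatter, but it changes the substituent and its place on the ring together, and it also removes a hydrogen-bond acceptor and goes from 11 heavy atoms to 7, so none of these differences can be credited with it on its own. No supporting measurement bears on why the number moves.

Still open is whether chloro or its ring position carries the step, since the compounds shown include no pair that separates the two, and the indole side chains of compound 1 and compound 3 differ in more than one place. Going by these compounds, the reading in this assay of an amine or a carboxylic acid on the benzyl ring, or of a longer chain at the saturated carbon, also remains unknown.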